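Moving the fluorine around the aryl on the triazole nitrogen

A few compounds are considered here, and "the series" means these few. Any claim that something is new, unique, unknown or untested is made for them only; others in the source may bear on it.

Compound 2 `O=c1[nH]cc(S(=O)(=O)Nc2cccc(-c3cn(-c4cccc(F)c4)nn3)c2)c(=O)[nH]1` gives 7200 nM in a functional assay on A549 cells (Homo sapiens) for antiproliferative activity, read by MTT assay, with a stated time of 24 h; on this read-out higher numbers stand for weaker inhibition and lower numbers for stronger inhibition; of the two compounds measured it has the higher number, its nearest neighbour being compound 1 `Cc1ccc(-n2cc(-c3cccc(NS(=O)(=O)c4c[nH]c(=O)[nH]c4=O)c3)nn2)cc1`, which gives 3630 nM in this assay. Among the compounds with values here, the only measured step, a 2.0-fold higher number from compound 1 to compound 2 (0.30 log units; within the scatter), lay within the scatter. Compound 3 `O=c1[nH]cc(S(=O)(=O)Nc2cccc(-c3cn(-c4ccc(F)cc4)nn3)c2)c(=O)[nH]1` carries 4-fluorophenyl in place of 3-fluorophenyl on an aromatic nitrogen. Within the data shown here, no measured step covers this exact change, and the one step that touches the same aromatic nitrogen was small, so the expected step of a 1.3-fold lower number from compound 2 to compound 3 (0.12 log units; within the scatter) is none beyond the scatter. Compound 3 is therefore estimated at 5500 nM, within 2000 nM to 15000 nM.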

Compound 3, half-maximal inhibitory concentration: > 20000 nM
Compound 3: only a limit was reported (the forecaster's own chance of this, stated with the estimate: 10%); middle value at least 3.6-fold (0.56 log units) from the limit.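

Compound 3 stands at a limit of the assay and not at a number: the limit of > 20000 nM in this assay, at which 1 of the 3 values shown sits. In this assay, within the data shown here, the same atoms joined differently, with 4-fluorophenyl in place of 3-fluorophenyl, give an at least 2.7-fold higher number from compound 2 to compound 3 (0.44 log units; beyond the scatter) and this is the first step on this aromatic nitrogen beyond the scatter, so where the fluorine sits counts, not merely its presence. Fluoro in place of methyl on the aromatic carbon gives an at least 5.5-fold higher number from compound 1 to compound 3 (0.74 log units; beyond the scatter) and so the group carried there matters as well. The compounds shown leave open how far the number of compound 3 lies beyond its limit, and whether a methoxy group, an amine or a carboxylic acid in that place would stay near compound 1.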